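From isopentyloxy to chloro on a shared core

The source may hold more compounds than are shown below. What is called first, only, known or untested is meant among the compounds shown, and "the series" means these compounds.

- compound 1 `CCOc1ccc2oc(/C=C/[S+](C)[O-])cc(=O)c2c1` gives 4900 nM
- compound 2 `CC(C)CCOc1ccc2oc(/C=C/[S+](C)[O-])cc(=O)c2c1` gives 4100 nM

In a functional assay on DLD-1 cells (Homo sapiens) for cytotoxicity, with a stated time of 48 h (a higher number here means a weaker inhibitor, a lower number a stronger inhibitor), compound 2 stands level with compound 1, their values lying within the scatter of each other. Compound 3 `C[S+]([O-])/C=C/c1cc(=O)c2cc(Cl)ccc2o1` brings a larger change: chloro in place of isopentyloxy on an aromatic carbon. Going by the values given here, the only measured step, a 1.2-fold lower number from compound 1 to compound 2 (0.08 log units; within the scatter), alters the chain alone and replaces no isopentyloxy group, so it is weak guidance. With no evidence for either direction, no shift beyond the scatter is expected, though uncertainty is wide. The expected step is a 1.1-fold higher number from compound 2 to compound 3 (0.04 log units; within the scatter). For compound 3 the estimated value is 4500 nM, with an expected range of 1500 nM to 13000 nM.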

Compound 3, half-maximal inhibitory concentration: 6500 nM
Estimate against measurement, compound 3: 1.4-fold (0.16 log units) below; low and high end bracket the measured number.
By their numbers in this assay, from the lowest: compounds 2, 1 and 3 (each within the scatter of the next).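

At this aromatic carbon, the whole oxygen-linked chain can give way to a single chloro with no readable shift in this assay: chloro in place of isopentyloxy gives a 1.6-fold higher number from compound 2 to compound 3 (0.20 log units; within the scatter) and chloro in place of ethoxy gives a 1.3-fold higher number from compound 1 to compound 3 (0.12 log units; within the scatter). The earlier pair varied only the chain, so it could not show that the ring oxygen and chain can both go. No supporting measurement bears on this result. Going by these compounds, whether an amine, a carboxylic acid or a much longer chain at this carbon would move the number beyond the scatter remains open.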